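This account rests on a few compounds, and the source may have more. Where it says the series, first, only, none or still open, it means among the compounds named here.

Compound 1 `Cc1cc(NC(=O)Cn2nnc(-c3ccccc3)n2)n(C2CCC(F)(F)CC2)n1` gives 84 nM in an assay on HEK293 cells for activation of Kir3.1/Kir3.2 (Homo sapiens), read by thallium flux; on this read-out higher numbers stand for an effect only at larger amounts of compound and lower numbers for an effect already at smaller amounts. Compound 2 `Cc1cc(NC(=O)Cn2nnc(-c3ccccc3)n2)n(C2CC2)n1` gives only a limit in this assay, > 5000 nM. Compound 3 `CC1(c2cc(NC(=O)Cn3nnc(-c4ccccc4)n3)n(C3CCCCC3)n2)CC1` likewise gives only a limit, > 10000 nM.

Compound 2 therefore stands at one of the two limits shown, (the limit of > 5000 nM in this assay, at which 1 of the 3 values shown sits), and compound 1 holds the only actual number. Going by the values given here, the single measured step, an at least 59-fold higher number from compound 1 to compound 2 (1.77 log units; beyond the scatter), shows that the group on the aromatic nitrogen can move the read-out by a large amount. Compound 4 `Cc1cc(NC(=O)Cn2nnc(-c3ccccc3)n2)n(Cc2ccccc2)n1` carries benzyl in place of cyclopropyl on an aromatic nitrogen. Because that same position is where an at least 59-fold higher number from compound 1 to compound 2 (1.77 log units; beyond the scatter) arose, a sizeable shift is expected again, and a return toward a measurable number seems the likelier direction: the step is estimated as an at least 2.5-fold lower number from compound 2 to compound 4 (0.39 log units; beyond the scatter). Compound 4 is thus expected to give about 2000 nM, within 300 nM to 10000 nM.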

Compound 4, half-maximal effective concentration: 495 nM
Estimate against measurement, compound 4: 4.0-fold (0.61 log units) above; the range from low to high includes it.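

Putting benzyl in place of cyclopropyl on the aromatic nitrogen brings back a measurable effect, an at least 10-fold lower number from compound 2 to compound 4 (1.00 log units; beyond the scatter). The size of that step has a floor rather than an exact value, as compound 2 holds only a limit: the limit of > 5000 nM in this assay, at which 1 of the 4 values shown sits. Benzyl still falls short of the 4,4-difluorocyclohexyl group, a 5.9-fold higher number from compound 1 to compound 4 (0.77 log units; beyond the scatter), so the ring on this nitrogen need not be saturated for an effect to be measured, but the choice of group still matters. Still open, as far as these compounds go, is how a longer chain ending in the same phenyl ring, or an amine on the benzyl ring, would read in this assay.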